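The source may hold more compounds than are shown below. What is called first, only, known or untested is meant among the compounds shown, and "the series" means these compounds.

Measured compounds:
compound 1, `Cc1nc(C(c2ccc(-c3ccc4cccc(F)c4c3)[nH]c2=O)C(C)C)[nH]c1C`: 7 nM
compound 2, `Cc1c[nH]c(C(c2ccc(-c3ccc4cccc(F)c4c3)[nH]c2=O)C(C)C)n1`: 12 nM

Both were read in an assay on CHO cells for displacement of a labelled ligand from prostaglandin E2 receptor EP3 subtype (Homo sapiens), read by radioligand binding; on this read-out higher numbers stand for weaker inhibition and lower numbers for stronger inhibition. Going by the values given here, compound 2 stands with the higher of the two numbers; its only neighbour is compound 1, and the step of a 1.7-fold higher number from compound 1 to compound 2 (0.23 log units; within the scatter) lies within the scatter, so the two cannot be put in order.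

Compound 3, `CC(C)C(Cc1noc(=O)[nH]1)c1ccc(-c2ccc3cccc(F)c3c2)[nH]c1=O`, has not been measured. Against compound 2 the change is a group of 7 heavy atoms (3 carbon, 2 nitrogen, 2 oxygen; one five-membered aromatic ring with 3 hetero atoms) in place of a group of 6 heavy atoms (4 carbon, 2 nitrogen; one five-membered aromatic ring with 2 hetero atoms), on a saturated chain carbon bound to an aromatic carbon and a saturated chain carbon.

Among the compounds with values here, the one measured step, a 1.7-fold higher number from compound 1 to compound 2 (0.23 log units; within the scatter), concerns a methyl swapped for hydrogen on an aromatic carbon of the very group that now leaves; it says nothing about exchanging one five-membered ring for another, and no other step bears on this change. The series therefore gives no direction. The expectation for compound 3 is set near compound 2 with a wide range, and the step of a 2.5-fold higher number from compound 2 to compound 3 (0.40 log units; beyond the scatter) is expected to stay modest. In this assay compound 3 is estimated at 30 nM, with a range from 5 nM to 200 nM.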

Compound 3, inhibition constant in the prostaglandin E2 receptor EP3 subtype assay: 34 nM
Estimate against measurement, compound 3: 1.1-fold (0.05 log units) below; the measured number falls inside the stated range.
By their numbers in the prostaglandin E2 receptor EP3 subtype assay, from the lowest: compounds 1 and 2 (each within the scatter of the next); then compound 3.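

The position, a saturated chain carbon bound to an aromatic carbon and a saturated chain carbon, accepts a five-membered aromatic ring with 3 hetero atoms, but in the prostaglandin E2 receptor EP3 subtype assay the exchange costs something: a 2.8-fold higher number from compound 2 to compound 3 (0.45 log units; beyond the scatter) and a 4.9-fold higher number from compound 1 to compound 3 (0.69 log units; beyond the scatter), which places compound 3 as the weakest of the three. Going by these compounds alone, the earlier methyl-for-hydrogen step stayed within the scatter, so this is the first change that moves the number beyond it, and it comes from replacing the ring itself rather than a substituent on it. In a physicochemical assay for solubility, measured as kinetic solubility, at pH 2 (on this read-out lower numbers stand for lower solubility and higher numbers for higher solubility), compound 2 gives 6300 nM and compound 3 gives 18200 nM, so the same exchange that weakens the binding number comes with a gain in solubility: the measured solubility of compound 2, 6300 nM, and of compound 3, 18200 nM, a 2.9-fold higher number (0.46 log units; beyond the scatter)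

The solubility gain rests on this single pair, and the compounds shown do not separate which part of the entering group accounts for either shift. On these data alone, whether a carboxylic acid or an amine on the same carbon would keep the number of compound 2 while matching the solubility of compound 3 remains open.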